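The compounds below may be only part of what the source reports. "The series", "measured", "known", "first", "only" and "open" are said of these compounds alone.

Working notes on the series. The shared core is carried by compound 3 `COc1ccc(/C=C\C(=O)O)c(OCc2cn(-c3ccc(CO)cc3)nn2)c1CC=C(C)C`, which in a functional assay on HCT-116 cells (Homo sapiens) for cytotoxicity, read by MTT assay, with a stated time of 24 h (on this read-out lower numbers stand for stronger inhibition and higher numbers for weaker inhibition), gives 31700 nM, the highest of the three numbers recorded so far. Compound 1 `COc1ccc(/C=C\C(=O)O)c(OCc2cn(-c3ccc(NC(=O)c4ccccc4)cc3)nn2)c1CC=C(C)C` gives 16400 nM in this assay, and compound 2 `COc1cccc(-n2cc(COc3c(/C=C\C(=O)O)ccc(OC)c3CC=C(C)C)nn2)c1` gives 21600 nM. Both neighbours sit close: a 1.9-fold higher number from compound 1 to compound 3 (0.29 log units; within the scatter), and a 1.5-fold higher number from compound 2 to compound 3 (0.17 log units; within the scatter), so no order among the three can be read from these numbers.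

The next compound, compound 4 `COc1ccc(/C=C\C(=O)O)c(OCc2cn(-c3cccc([N+](=O)[O-])c3)nn2)c1CC=C(C)C`, is not yet measured in this assay. It differs from compound 3 in one place: 3-nitrophenyl in place of 4-(hydroxymethyl)phenyl on an aromatic nitrogen. For the measured compounds named here, the step that bears most directly on it is the one from compound 2 to compound 3, since it also swaps the whole aryl group on the same aromatic nitrogen, and that step stayed within the scatter. The step from compound 1 to compound 3, which alters a substituent on that aryl group, also stayed within the scatter. Every change tried at this position has therefore left the number essentially where it was, and no shift beyond the scatter is expected for compound 4: its step from compound 3 is estimated as a 1.3-fold lower number from compound 3 to compound 4 (0.10 log units; within the scatter). Compound 4 is expected to give about 25000 nM in this assay, with a range of 10000 nM to 60000 nM.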

Compound 4, half-maximal inhibitory concentration: 27300 nM
For compound 4 the middle estimate is 1.1-fold (0.04 log units) below the measured one, within the range that was stated.
By their numbers in this assay, from the lowest: compounds 1, 2, 4 and 3 (each within the scatter of the next).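

In this assay the step of a 1.2-fold lower number from compound 3 to compound 4 (0.06 log units; within the scatter) stays within the scatter even though the group on the aromatic nitrogen changes from one with 1 hydrogen-bond donor and 1 hydrogen-bond acceptor to one with 0 hydrogen-bond donors and 2 hydrogen-bond acceptors, so this change in the counts leaves no readable mark on the number. For the compounds shown here, the step of a 1.3-fold higher number from compound 2 to compound 4 (0.10 log units; within the scatter) is the first to isolate a single substituent on the 3-substituted aryl group, and nitro in place of methoxy also stays within the scatter. Taken together, the four compounds now tolerate a benzamido, hydroxymethyl, methoxy or nitro substituent on this aryl group without any step leaving the scatter, though all of their numbers remain high in this assay.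

Still open, from the compounds shown here alone, is whether an amine or a carboxylic acid on the aryl group, or a longer alkyl chain in place of that aryl group on the aromatic nitrogen, would move the number beyond the scatter. The compounds shown also leave open whether 4-nitrophenyl would give a number different from that of 3-nitrophenyl. No measurement is at hand that would explain how closely these numbers sit together.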